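The source may hold more compounds than are shown below. What is called first, only, known or untested is meant among the compounds shown, and "the series" means these compounds.

Compound 1 `COc1cc(-c2nn(-c3cccc(NC(=O)Nc4cc(C(F)(F)F)cc(C(F)(F)F)c4)c3)cc2-c2ccncc2)ccc1Cl`: 531 nM
Compound 2 `COc1cc(-c2nn(-c3cccc(NC(=O)c4cccc(C(F)(F)F)c4)c3)cc2-c2ccncc2)ccc1Cl`: 1660 nM

Both numbers come from a functional assay on KM12 cells (Homo sapiens) for inhibition, read by sulforhodamine B assay, with a stated time of 48 h; on this read-out higher numbers stand for weaker inhibition of growth and lower numbers for stronger inhibition of growth. On these two values compound 2 stands highest, compound 1 gives the lower number, and the gap between them lies beyond the usual scatter of repeated measurements. Compound 3 `COc1cc(-c2nn(-c3cccc(NC(=O)Nc4ccc(Cl)c(Cl)c4)c3)cc2-c2ccncc2)ccc1Cl` has not yet been measured. It differs from compound 2 in a single place: (3,4-dichlorophenyl)amino in place of 3-(trifluoromethyl)phenyl on a carbonyl carbon. The carbonyl that carries an aryl group in compound 2 therefore carries an arylamino group in compound 3, the same arrangement found in compound 1, where an arylamino group also sits on the carbonyl. For the measured compounds named here, no measured pair shows this exact change, so the size of the step cannot be read directly from the data. The basis for an expectation is compound 1, which with its arylamino group on the carbonyl gives 531 nM in this assay. The expected step is a 2.8-fold lower number from compound 2 to compound 3 (0.44 log units; beyond the scatter), toward a lower number and beyond the scatter. Compound 3 is estimated at 600 nM, with a range from 200 nM to 1800 nM.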

Compound 3, concentration for 50% growth inhibition: 811 nM
Compound 3: the middle estimate sits 1.4-fold (0.13 log units) below what was measured, and the stated range covers the measured number.
By their numbers in this assay, from the lowest: compounds 1 and 3 (each within the scatter of the next); then compound 2.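

In this assay, putting (3,4-dichlorophenyl)amino in place of 3-(trifluoromethyl)phenyl on a carbonyl carbon gives a 2.0-fold lower number from compound 2 to compound 3 (0.31 log units; beyond the scatter), a modest step, but the first at this position that can be read as a change in one place. It shows that this place accepts an arylamino group bearing chlorine atoms as well as an aryl group bearing trifluoromethyl, and that growth inhibition grows somewhat stronger with the exchange, although the exchange brings in a nitrogen with its hydrogen-bond donor and alters the ring's substituents at the same time, so the step belongs to the whole swap and not to either part alone. Nothing available gives a reason for this step.

On these data alone, whether the nitrogen or the ring's substituents carry the step remains open, and (3-(trifluoromethyl)phenyl)amino on the same carbonyl carbon would separate the two. Also open, as far as these compounds go, is how this place responds to a group without an aromatic ring, such as a simple alkylamine, or to an aryl ring bearing a carboxylic acid.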